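The source may report more compounds than this note shows. Statements on the series, on what has been measured and on what is new or still open speak of the compounds shown alone.

Measured so far in an assay on isolated protein for inhibition of 2-Hydroxyacid oxidase 2 (Rattus norvegicus); on this read-out lower numbers stand for stronger inhibition and higher numbers for weaker inhibition:
- compound 1 `Cc1n[nH]c(C(=O)O)c1Cc1cccc(-c2ccccc2F)c1`: 900 nM
- compound 2 `Cc1n[nH]c(C(=O)O)c1Cc1ccc(-c2ccc(F)cc2)cc1`: 400 nM

Compound 1 carries the highest number of the two; the nearest is compound 2, which in this assay gives 400 nM, whereas compound 1 gives 900 nM, a gap beyond the usual scatter. For the measured compounds named here, the two differ in more than one place, so no single-point step between them can be read; their values only show that compound 2 sits lower.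

The next compound to be measured is compound 3 `Cc1n[nH]c(C(=O)O)c1Cc1cccc(OC(F)(F)F)c1`. Relative to compound 1 the change is trifluoromethoxy in place of 2-fluorophenyl on an aromatic carbon; the biaryl arm of compound 1 is thus exchanged for a single small substituent at the same ring carbon. Going by the values given here, no comparable step has yet been measured, so the size of the effect rests on expectation alone. A moderate move toward a higher number is expected, the estimated step being a 2.0-fold higher number from compound 1 to compound 3 (0.30 log units; within the scatter), though a result within the scatter of compound 1 cannot be excluded. In this assay compound 3 is expected at about 1800 nM, with a plausible range of 500 nM to 7000 nM.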

Compound 3, half-maximal inhibitory concentration: 700 nM
Compound 3: the middle estimate sits 2.6-fold (0.41 log units) above what was measured; measured number inside the range.
By their numbers in this assay, from the lowest: compounds 2, 3 and 1 (each within the scatter of the next, the first and the last beyond it).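

In this assay the exchange of 2-fluorophenyl for trifluoromethoxy on this aromatic carbon gives a 1.3-fold lower number from compound 1 to compound 3 (0.11 log units; within the scatter) and so separates the two groups by no more than the usual scatter. The second aromatic ring of compound 1 is thus not required at this carbon for a reading of this order: trifluoromethoxy, with no ring and with a hydrogen-bond acceptor that 2-fluorophenyl lacks, reads alike within the scatter. No measurement at hand accounts for this equivalence.

Compound 2 differs from compound 1 and from compound 3 in more than one place, so neither of those steps can be read, and the separate contributions of the fluorine placement and the attachment point of the biaryl arm remain unresolved. Also open, going by these compounds, is how far this tolerance extends at the same ring carbon, for instance whether a plain hydrogen, a methoxy group, an amine or a longer alkyl chain would still stay within the scatter of compound 1 and compound 3.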